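Fluorine step on the pendant ring, compound 4 expected

A few compounds are considered here, and "the series" means these few. Any claim that something is new, unique, unknown or untested is made for them only; others in the source may bear on it.

Compound 1 `O=c1c(-c2ccccc2)coc2cc(OC/C(=N/O)c3ccccc3)ccc12` and compound 2 `O=c1c(-c2ccccc2)coc2cc(OC/C(=N/O)c3ccc(F)cc3)ccc12` share one core; compound 2 differs from compound 1 as fluoro in place of hydrogen on an aromatic carbon. In a functional assay on SK-HEP1 cells (Homo sapiens) for antiproliferative activity (a higher number here means a weaker inhibitor of growth, a lower number a stronger inhibitor of growth), compound 1 gives 6400000 nM, and compound 2 gives 6610000 nM; the step of a 1.0-fold higher number from compound 1 to compound 2 (0.01 log units; within the scatter). Compound 3 `CO/N=C(/COc1ccc2c(=O)cc(-c3ccccc3)oc2c1)c1ccccc1` carries a different core; the difference between the core of compound 1 and the core of compound 3 is not broken down here. In this assay compound 3 gives 2000000 nM, the lowest of the three numbers, its gaps to compound 1 and to compound 2 both beyond the scatter. Compound 4 `CO/N=C(/COc1ccc2c(=O)cc(-c3ccccc3)oc2c1)c1ccc(F)cc1` is not yet measured; it differs from compound 3 as fluoro in place of hydrogen on an aromatic carbon, the same change as between compound 1 and compound 2, at a place described in the same words. Because the earlier step of a 1.0-fold higher number from compound 1 to compound 2 (0.01 log units; within the scatter) lies within the scatter, a step of similar size is expected in this assay, no change at the digits printed from compound 3 to compound 4 (within the scatter). Compound 4 is therefore estimated at 2000000 nM in this assay, the range running from 900000 nM to 4500000 nM.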

Compound 4, concentration for 50% growth inhibition: 3300000 nM
Estimate against measurement, compound 4: 1.7-fold (0.22 log units) below; the measured number falls inside the stated range.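

In this assay, the change from phenyl to 4-fluorophenyl gives a 1.7-fold higher number from compound 3 to compound 4 (0.22 log units; within the scatter), and on the other core the same change gives a 1.0-fold higher number from compound 1 to compound 2 (0.01 log units; within the scatter). Set side by side, the two steps agree: the same change on two cores in this assay, a 1.0-fold higher number (0.01 log units; within the scatter) from compound 1 to compound 2 and a 1.7-fold higher number (0.22 log units; within the scatter) from compound 3 to compound 4, 1.6-fold (0.20 log units) apart, within the scatter of two such steps. This shows that, on these two cores, the change carries over without a step beyond the scatter in this one cellular read-out, but with one pair per core it does not show that the same would hold on a further core or in another assay.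

Still open, as far as these compounds go, is whether a different group at the same place, para to a large group, such as chloro, methoxy, an amine or a carboxylic acid, would give a step beyond the scatter on either core. Also open, from the compounds shown here alone, is whether such a group would then carry over from the core of compound 1 to the core of compound 3 as fluoro does.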